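The source may report more compounds than this note shows. Statements on the series, on what has been measured and on what is new or still open speak of the compounds shown alone.

Among the compounds with values here, in a functional assay on CCRF-CEM cells (Homo sapiens) for antiproliferative activity, with a stated time of 72 h (a higher number here means a weaker inhibitor, a lower number a stronger inhibitor), three compounds built on one shared core have numbers so far. Compound 1 `OC[C@H]1O[C@@H](n2cnc3c(NCc4cccc(F)c4)ncnc32)[C@H](O)[C@@H]1O` gives 4000 nM, compound 2 `OC[C@H]1O[C@@H](n2cnc3c(NCc4ccc(F)cc4)ncnc32)[C@H](O)[C@@H]1O` gives 1250 nM, and compound 3 `OC[C@H]1O[C@@H](n2cnc3c(NCc4ccccc4Br)ncnc32)[C@H](O)[C@@H]1O` gives 12300 nM, which makes compound 3 the weakest inhibitor of the three. Compound 4 `OC[C@H]1O[C@@H](n2cnc3c(NCc4cccc(Br)c4)ncnc32)[C@H](O)[C@@H]1O` is still unmeasured. Its difference from compound 3 is 3-bromophenyl in place of 2-bromophenyl on a saturated chain carbon bound to a nitrogen on an aromatic ring, with 3-bromophenyl in place of 2-bromophenyl on a saturated chain carbon bound to a nitrogen on an aromatic ring.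

Within the data shown here, no measured compound carries 3-bromophenyl, so the evidence is indirect. The closest comparison is a 3.1-fold higher number from compound 1 to compound 3 (0.49 log units; beyond the scatter), since compound 1 has 3-fluorophenyl at that place. The other two steps are a 9.8-fold higher number from compound 2 to compound 3 (0.99 log units; beyond the scatter) and a 3.2-fold lower number from compound 1 to compound 2 (0.51 log units; beyond the scatter). Among the measured compounds shown here, compound 3 has the higher number in both steps that involve it, so a step toward a lower number is expected, similar in size to the one separating compound 1 and compound 3. The expected change is a 3.1-fold lower number from compound 3 to compound 4 (0.49 log units; beyond the scatter). For compound 4 the estimated value is 4000 nM, with an expected range of 1400 nM to 11000 nM.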

Compound 4, half-maximal inhibitory concentration: 5000 nM
Compound 4: middle estimate off by 1.3-fold (0.10 log units), on the low side; low and high end bracket the measured number.
By their numbers in this assay, from the lowest: compound 2; then compounds 1 and 4 (each within the scatter of the next); then compound 3.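

In this assay, the two bromo compounds hold the same atoms, joined differently, so the place of the bromine on the phenyl ring alone changes the number (a 2.5-fold lower number from compound 3 to compound 4 (0.39 log units; beyond the scatter)). With the ring place held, bromo in place of fluoro on an aromatic carbon stays within the scatter (a 1.3-fold higher number from compound 1 to compound 4 (0.10 log units; within the scatter)), while 3-bromophenyl in place of 4-fluorophenyl leaves a gap beyond it (a 4.0-fold higher number from compound 2 to compound 4 (0.60 log units; beyond the scatter)). Nothing available explains any of these steps.

Still open, going by these compounds, is how 4-bromophenyl and 2-fluorophenyl would stand, the two entries that would show whether the order of ring places seen so far holds for each halogen. Also open, on these data alone, is whether a methoxy group or a carboxylic acid at these ring places would follow the halogens.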